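This account rests on a few compounds, and the source may have more. Where it says the series, first, only, none or still open, it means among the compounds named here.

Working notes on the series in a functional assay on LOX IMVI cells (Homo sapiens) for inhibition, read by sulforhodamine B assay, with a stated time of 48 h; on this read-out lower numbers stand for higher toxicity in this test and higher numbers for lower toxicity in this test.

Going by the values given here, compound 2 `COc1cc(-c2nn(-c3cccc(NC(=O)Nc4ccc(Cl)c(C(F)(F)F)c4)c3)cc2-c2ccncc2)ccc1Cl` is the only compound of the pair with a numerical result: in this assay compound 2 gives 17900 nM. Compound 1 `COc1cc(-c2nn(-c3cccc(NC(=O)c4cccc(C(F)(F)F)c4)c3)cc2-c2ccncc2)ccc1Cl` returns only a limit of the assay, > 50000 nM in this assay, and no number. Among the compounds with values here, the one measured step therefore runs from a limit to a number: an at least 2.7-fold lower number from compound 1 to compound 2 (0.44 log units; beyond the scatter), which rests on (the limit of > 50000 nM in this assay, at which 1 of the 2 values shown sits).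

Compound 3 `COc1cc(-c2nn(-c3cccc(NC(=O)c4ccccc4)c3)cc2-c2ccncc2)ccc1Cl` is the next member. Relative to compound 2 the change is phenyl in place of (4-chloro-3-(trifluoromethyl)phenyl)amino on a carbonyl carbon. This removes the (4-chloro-3-(trifluoromethyl)phenyl)amino group whose entry, in the step from compound 1 to compound 2, brought the number down from the limit by an at least 2.7-fold lower number from compound 1 to compound 2 (0.44 log units; beyond the scatter). Compound 3 keeps the carbonyl carbon bound to the amide-type nitrogen, as compound 1 does, but carries a bare phenyl rather than the 3-(trifluoromethyl)phenyl of compound 1. The step from compound 2 to compound 3 is thus expected to go back up in this assay, roughly reversing that step, as a 2.2-fold higher number from compound 2 to compound 3 (0.35 log units; beyond the scatter), with a fair chance that only a limit is reported. The estimate for compound 3 in this assay is 40000 nM, within 15000 nM to 110000 nM.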

Compound 3, concentration lethal to 50% of the cells: > 100000 nM
Compound 3: no number, only a limit; the forecaster's own chance of this, stated with the estimate: 55%; at least 2.5-fold (0.39 log units) between middle value and limit.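

On the carbonyl carbon, phenyl in place of (4-chloro-3-(trifluoromethyl)phenyl)amino gives an at least 5.5-fold higher number from compound 2 to compound 3 (0.74 log units; beyond the scatter) in this assay, so the number of compound 2 now stands apart from two partners that carry no such group. Compound 3 gives only a limit, > 100000 nM, so the size of this step has a floor and no upper end. The step between compound 1 and compound 3, hydrogen in place of trifluoromethyl on an aromatic carbon, cannot be read because the two values are limits: the limit of > 100000 nM in this assay, at which 1 of the 3 values shown sits.

The amino nitrogen, the chlorine and the trifluoromethyl all leave together in the change from compound 2 to compound 3, and the compounds shown do not separate their shares in the step. Open too, as far as these compounds go, is how a plain phenylamino group, or a saturated amine such as piperidine, on the same carbonyl carbon would read in this assay.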